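Hydroxyl for Propoxy on the Anilide of Compound 1

The source may report more compounds than this note shows. Statements on the series, on what has been measured and on what is new or still open speak of the compounds shown alone.

Measured compounds:
compound 1, `CCCOc1ccc(NC(=O)CSc2nnc(Cc3nn(C)c(=O)c4ccccc34)n2C)cc1`: > 30000 nM
compound 2, `Cn1c(Cc2nn(C)c(=O)c3ccccc23)nnc1SCCCCCC(=O)Nc1ccc(Cl)cc1Cl`: 4100 nM
compound 3, `Cn1c(Cc2nn(C)c(=O)c3ccccc23)nnc1SCCCCCCCCCCC(=O)Oc1ccc(Cl)cc1Cl`: 8700 nM

Of the compounds shown here, three with a shared core have been tested in an assay on isolated protein (Mus musculus) for inhibition of IL15-IL15 receptor (Homo sapiens), read by resazurin assay, with stated times of 30 min and 2.5 days; a higher number here means a weaker inhibitor, a lower number a stronger inhibitor. Compound 1 stands apart in that it returns no number: in this assay compound 1 gives > 30000 nM, which is a limit of the assay rather than a measured value (the limit of > 30000 nM in this assay, at which 1 of the 3 values shown sits). The other two do give numbers: compound 2 gives 4100 nM in this assay, and compound 3 gives 8700 nM. For the measured compounds named here, no two of the measured compounds differ in only one place, so no single measured step is available to calibrate the change that follows.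

Compound 4, `Cn1c(Cc2nn(C)c(=O)c3ccccc23)nnc1SCC(=O)Nc1ccc(O)cc1`, differs from compound 1 by hydrogen in place of propyl on an oxygen on an aromatic ring, propoxy becoming hydroxy. Going by the values given here, with compound 1 at a limit, the direction of the step can only be read toward stronger inhibition, if at all, and nothing among the measured compounds shows how large such a change would be.

Compound 4 is therefore expected to sit near the limit as well, estimated at 25000 nM with a range from 6000 nM to 80000 nM. The step expected from compound 1 to compound 4 is an at least 1.2-fold lower number from compound 1 to compound 4 (0.07 log units; that floor lies within the scatter), and a fair chance remains that this assay again reports only a limit for compound 4.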

Compound 4, half-maximal inhibitory concentration: "not active" (no number reported)
For compound 4 the study gives words and no number, and the estimate cannot be compared.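

For the compounds shown here, no step from compound 1 to compound 4 can be read, since compound 4 is reported in this assay only in the words "not active". Compound 1 gives > 30000 nM, which is a limit of the assay and not a number. The compounds shown leave open whether hydroxy in place of propoxy changes inhibition at all, and by how much.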